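A tert-butoxycarbonyl tail in place of a sulfonylpiperazine

The compounds below may be only part of what the source reports. "The series", "measured", "known", "first", "only" and "open" are said of these compounds alone.

Measured so far in an assay on HEK293 cells for displacement of a labelled ligand from NPC1-like intracellular cholesterol transporter 1 (Homo sapiens); a lower number here means a stronger inhibitor, a higher number a weaker inhibitor:
compound 1 `CS(=O)(=O)NCCCNC(=O)CN1CN(c2ccccc2)C2(CCN(C(=O)c3ccc(C4CCCCC4)cc3)CC2)C1=O`: 3800 nM
compound 2 `CS(=O)(=O)N1CCN(C(=O)CN2CN(c3ccccc3)C3(CCN(C(=O)c4ccc(C5CCCCC5)cc4)CC3)C2=O)CC1`: 6300 nM
compound 3 `O=C(CN1CN(c2ccccc2)C2(CCN(C(=O)c3ccc(C4CCCCC4)cc3)CC2)C1=O)N1CCN(S(=O)(=O)c2ccccc2)CC1`: 14200 nM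

Compound 2 stands second highest of these three numbers. Its nearest neighbour is compound 1, with a 1.7-fold higher number from compound 1 to compound 2 (0.22 log units; within the scatter); its furthest is compound 3, with a 2.3-fold higher number from compound 2 to compound 3 (0.35 log units; beyond the scatter).

The unmeasured compound 4 `CC(C)(C)OC(=O)NCCCNC(=O)CN1CN(c2ccccc2)C2(CCN(C(=O)c3ccc(C4CCCCC4)cc3)CC2)C1=O` differs from compound 2 in one place: (3-((tert-butoxycarbonyl)amino)propyl)amino in place of 4-(methylsulfonyl)piperazin-1-yl on a carbonyl carbon. Among the compounds with values here, one measured step bears directly on this change. The step from compound 1 to compound 2 exchanged a (3-(methanesulfonamido)propyl)amino for the same 4-(methylsulfonyl)piperazin-1-yl and gave a 1.7-fold higher number from compound 1 to compound 2 (0.22 log units; within the scatter), so the return from the piperazine to a propylamino chain is expected to stay within the scatter. Within the data shown here, no measured step shows what a tert-butoxycarbonyl group does in place of a methanesulfonyl group on the terminal nitrogen of that chain; the step from compound 2 to compound 3, a 2.3-fold higher number from compound 2 to compound 3 (0.35 log units; beyond the scatter), concerns a different group at a different place and is at most a loose guide that a bulkier terminus did not help there.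

Compound 4 is therefore expected to give about 4500 nM in this assay, with a range from 1500 nM to 14000 nM. This estimate corresponds to an expected 1.4-fold lower number from compound 2 to compound 4 (0.15 log units; within the scatter).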

Compound 4, half-maximal inhibitory concentration: 6000 nM
Compound 4: middle estimate off by 1.3-fold (0.12 log units), on the low side; measured number inside the range.
By their numbers in this assay, from the lowest: compounds 1, 4 and 2 (each within the scatter of the next); then compound 3.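

In this assay, replacing the 4-(methylsulfonyl)piperazin-1-yl on the carbonyl carbon with (3-((tert-butoxycarbonyl)amino)propyl)amino gave a 1.1-fold lower number from compound 2 to compound 4 (0.02 log units; within the scatter), so this assay does not separate the ring-bearing group from the open chain with its new terminus. The direct comparison on the amine nitrogen of the chain, tert-butoxycarbonyl in place of methylsulfonyl, gave a 1.6-fold higher number from compound 1 to compound 4 (0.20 log units; within the scatter), which shows that among these compounds a sulfonyl group on that nitrogen is not needed to stay within the scatter of compound 1. Within the data shown here, compounds 1, 2 and 4 thus read alike despite their different groups at this position, and the one step here beyond the scatter remains the phenyl on the sulfonyl sulfur, a 2.3-fold higher number from compound 2 to compound 3 (0.35 log units; beyond the scatter).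

Nothing available explains why these different groups read alike in this assay. The compounds shown leave open whether a free amine or a carboxylic acid at the end of the chain, or a longer chain on the carbonyl carbon, would move the number beyond the scatter in either direction.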